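Nitro for Chloro in a Weakly Cytotoxic Series

The source may hold more compounds than are shown below. What is called first, only, known or untested is meant among the compounds shown, and "the series" means these compounds.

Measured compounds:
compound 1 `COc1cc(-c2nnc3n2NC(c2ccco2)C(C(=O)c2ccc(Cl)cc2)S3)cc(OC)c1OC` — 78600 nM
compound 2 `COc1cc(C(=O)C2Sc3nnc(-c4cc(OC)c(OC)c(OC)c4)n3NC2c2cccs2)cc(OC)c1OC` — > 100000 nM

Within the data shown here, in a functional assay on HepG2 cells (Homo sapiens) for cytotoxicity, read by MTT assay, with a stated time of 48 h (on this read-out higher numbers stand for weaker inhibition and lower numbers for stronger inhibition), compound 1 gives 78600 nM, the only plain number recorded in this set. For compound 2 the entry > 100000 nM is a limit of the assay and not a number, as noted in the limit of > 100000 nM in this assay, at which 1 of the 2 values shown sits. Among the measured compounds shown here, no pair of measured compounds differs in a single place, so no measured step exists to calibrate the change considered here.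

Compound 3 `COc1cc(-c2nnc3n2NC(c2ccco2)C(C(=O)c2ccc([N+](=O)[O-])cc2)S3)cc(OC)c1OC` is compound 1 with nitro in place of chloro on an aromatic carbon. For the measured compounds named here, with no measured step to draw on, the expectation is a step of a 1.0-fold higher number from compound 1 to compound 3 (0.01 log units; within the scatter) that stays within the usual scatter, in no particular direction. Compound 3 is therefore expected to give about 80000 nM, with a range of 30000 nM to 200000 nM, and a fair chance that only a limit is reported.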

Compound 3, half-maximal inhibitory concentration: 87800 nM
Estimate against measurement, compound 3: 1.1-fold (0.04 log units) below; low and high end bracket the measured number.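

In this assay, the series now has its first measured step, nitro in place of chloro on the aromatic carbon: a 1.1-fold higher number from compound 1 to compound 3 (0.05 log units; within the scatter). At this position, 4-chlorophenyl and 4-nitrophenyl therefore cannot be told apart, even though nitro brings hydrogen-bond acceptors and chloro brings none. Compound 2 carries a limit and not a number: the limit of > 100000 nM in this assay, at which 1 of the 3 values shown sits.

As far as these compounds go, whether a 4-aminophenyl or 4-carboxyphenyl group in place of 4-chlorophenyl would give a step beyond the scatter remains open. Among these compounds, compound 2 differs from compound 1 in more than one place, so no step calibrates any other part of the shared core.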